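A few compounds are considered here, and "the series" means these few. Any claim that something is new, unique, unknown or untested is made for them only; others in the source may bear on it.

Measured compounds:
- compound 1, `COc1ccc2nc(C)cc(NCC(=O)Nc3cc(C)cc(C)c3)c2c1`: 3.59
- compound 2, `COc1ccc2nc(C)cc(OCC(=O)Nc3cc(C)ccc3C)c2c1`: 5.05

Both were read in a physicochemical assay for lipophilicity, read by HPLC, in phosphate buffer, measured as chromatographic lipophilicity, at pH 7.4; on this read-out higher numbers stand for higher lipophilicity and lower numbers for lower lipophilicity. Compound 2 gives 5.05, the higher of the two numbers; its nearest neighbour, compound 1, stands lower by a gap beyond the usual scatter. For the measured compounds named here, no pair of compounds that differ in a single place has been measured, so no step in this assay can be read off directly from these two.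

Compound 3, `COc1ccc2nc(C)cc(OCC(=O)Nc3ccc(Cl)c(OC)c3)c2c1`, has not yet been run in this assay. It differs from compound 2 in one place: 4-chloro-3-methoxyphenyl in place of 2,5-dimethylphenyl on an amide-type nitrogen. Both groups in this exchange are a single six-membered aromatic ring of carbon only and carry no net charge. Going by the values given here, because compound 2 sits at 5.05 and no measured step of this kind exists, the expectation rests on that value alone. The step of a number 0.25 log units lower from compound 2 to compound 3 (within the scatter) is expected to be small, within or at the edge of the usual scatter, if anything leaning towards lower values. Compound 3 is therefore estimated at 4.8, with a range from 4.3 to 5.3.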

Compound 3, distribution coefficient: 5.09
Estimate against measurement, compound 3: 0.29 log units below, and the stated range covers the measured number.
By their numbers in this assay, from the lowest: compound 1; then compounds 2 and 3 (each within the scatter of the next).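

In this assay, for the compounds shown here, 4-chloro-3-methoxyphenyl in place of 2,5-dimethylphenyl on the amide-type nitrogen gives a number 0.04 log units higher from compound 2 to compound 3 (within the scatter), the first single-place step. At this place, the entering group, with 9 heavy atoms including an oxygen and a chlorine and with 1 hydrogen-bond acceptor, cannot be told apart in this read-out from the leaving group, with 8 heavy atoms, all carbon, and 0 hydrogen-bond acceptors, although this rests on one pair only. No measured evidence bears on why these two groups read alike.

Compound 1 differs from compound 2 and from compound 3 in more than one place, so its gap to them cannot be read as a step, and the contribution of the link at the shared core remains unresolved. Also open, going by these compounds, is whether the same place would tolerate a non-aromatic substituent, such as a group bearing an amine or a carboxylic acid, or a longer chain, as it tolerates this exchange between two substituted phenyl groups.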